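A few compounds are considered here, and "the series" means these few. Any claim that something is new, unique, unknown or untested is made for them only; others in the source may bear on it.

Measured so far in an ADME assay on Vero cells (Chlorocebus sabaeus) for cytotoxicity; a higher number here means that more compound is tolerated, a lower number that less compound is tolerated:

compound 1, `c1cc(NC2CCCC2)c2nc(-c3ccc(OCC4CC4)cc3)c(-c3ccnc(NC4CCCC4)n3)n2c1` – > 40000 nM
compound 2, `C=CCOc1cccc(-c2nc3c(NC4CCCC4)cccn3c2-c2ccnc(NC3CCCC3)n2)c1` – > 40000 nM

In this assay compound 1 gives > 40000 nM, which is a limit of the assay and not a number. Compound 2 gives > 40000 nM in this assay, likewise a limit. The step that the two limits leave unreadable from compound 1 to compound 2 is therefore not readable in size or direction; all that the two values show is that both sit at the limit of > 40000 nM in this assay, at which 2 of the 2 values shown sit.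

Compound 3, `N#Cc1ccc(-c2nc3c(NC4CCCC4)cccn3c2-c2ccnc(NC3CCCC3)n2)cc1`, differs from compound 2 by 4-cyanophenyl in place of 3-(allyloxy)phenyl on an aromatic carbon. Among the measured compounds shown here, no measured step bears directly on this change: the one step recorded is unreadable, and it exchanges a different pair of groups. With both measured compounds at the limit, the expectation for compound 3 is that this assay again reports a limit. Compound 3 is estimated at 45000 nM, with a range from 20000 nM to 120000 nM. The expected step that the limit leaves unreadable from compound 2 to compound 3 is none beyond the scatter.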

Compound 3, half-maximal cytotoxic concentration: > 40000 nM
Compound 3 was reported as a limit (the forecaster's own chance of this, stated with the estimate: 70%); the middle value does not contradict the limit.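

In this assay compound 3 gives > 40000 nM, which is a limit of the assay and not a number. No step among compound 1, compound 2 and compound 3 can be read: the limit of > 40000 nM in this assay, at which 3 of the 3 values shown sit.

The compounds shown leave open how far apart these three lie and which change on the shared core would give a readable value in this assay.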